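From Fluoro to Acetyl: Expecting the Next Dose

The source may report more compounds than this note shows. Statements on the series, on what has been measured and on what is new or still open speak of the compounds shown alone.

Of the compounds shown here, two have been measured in a functional assay on the whole organism for inhibition, with Rattus norvegicus as the target; a lower number here means that less compound is needed, a higher number that more compound is needed for the effect. Compound 1 `O=C(O)c1cnc2n(c1=O)CCC/C2=N\Nc1ccccc1` gives 31.6 umol/kg in this assay. Compound 2 `CC1CC/C(=N\Nc2ccc(F)cc2)c2ncc(C(=O)O)c(=O)n21` gives 12.2 umol/kg in this assay, the lower of the two numbers, and its gap to compound 1 lies beyond the usual scatter of repeated measurements. Compound 3 `CC(=O)c1ccc(N/N=C2\CCC(C)n3c2ncc(C(=O)O)c3=O)cc1` has not yet been measured. It differs from compound 2 in one place: acetyl in place of fluoro on an aromatic carbon. Among the measured compounds shown here, no measured pair here shows what such a swap does, so any expectation rests on compound 2 alone. With nothing to suggest a large move in either direction, the change in this assay is expected to be small, a 1.2-fold higher number from compound 2 to compound 3 (0.09 log units; within the scatter), and not clearly beyond the scatter. Compound 3 is therefore estimated at 15 umol/kg, with a plausible range from 5 umol/kg to 50 umol/kg.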

Compound 3, dose for 50% inhibition: 9.5 umol/kg
Compound 3: middle estimate off by 1.6-fold (0.20 log units), on the high side; measured number inside the range.
By their numbers in this assay, from the lowest: compounds 3 and 2 (each within the scatter of the next); then compound 1.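

At this place on the aromatic ring, para to a large group, the swap can now be read directly: in this assay acetyl in place of fluoro gives a 1.3-fold lower number from compound 2 to compound 3 (0.11 log units; within the scatter) and the two compounds cannot be told apart. So the position takes acetyl, with its 3 heavy atoms and 1 hydrogen-bond acceptor, as well as the single fluorine atom, at least in this pair. Nothing measured here explains why the two numbers lie so close.

From the compounds shown here alone, it remains open whether the same holds for quite different groups at this place, such as an amine, a carboxylic acid or a longer chain. A single pair also cannot show whether this swap would behave the same way on another core.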